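The compounds below may be only part of what the source reports. "The series", "measured", "known", "first", "only" and "open" are said of these compounds alone.

Compound 1 `COC1Cc2c(cnn2-c2ccccc2)C2(CCN(Cc3ccco3)CC2)O1`: in an assay for displacement of a labelled ligand from Sigma non-opioid intracellular receptor 1 (Cavia porcellus), read by scintillation counting, with a stated time of 180 min (a higher number here means a weaker inhibitor, a lower number a stronger inhibitor), compound 1 gives 2.2 nM.
Compound 2 `COC1Cc2c(cnn2-c2ccccc2)C2(CCN(CC(C)C)CC2)O1`: in this assay compound 2 gives 6.3 nM.
Compound 3 `C1=Cc2c(cnn2-c2ccccc2)C2(CCN(Cc3ccccc3)CC2)O1`: in this assay compound 3 gives 1.48 nM.

Compound 3 has the lowest of the three numbers. Compound 1 stands nearest to it, within the scatter, while compound 2 stands furthest, beyond the scatter. Compound 4 `Cn1ncc2c1C=COC21CCN(Cc2ccccc2)CC1` differs from compound 3 by methyl in place of phenyl on an aromatic nitrogen. Going by the values given here, the only measured step, a 2.9-fold higher number from compound 1 to compound 2 (0.46 log units; beyond the scatter), concerns the group on the amine nitrogen, a different part of the shared core, so it does not bear directly on this change; it shows only that swapping one group for a smaller one at another place moved the number modestly. Among the compounds with values here, with no measured step at the aromatic nitrogen, the expectation for compound 4 is a modest step toward a higher number, a 3.0-fold higher number from compound 3 to compound 4 (0.48 log units; beyond the scatter), with the estimate for compound 4 in this assay being 4.5 nM, ranging from 1.5 nM to 15 nM.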

Compound 4, inhibition constant: 12 nM
Estimate against measurement, compound 4: 2.7-fold (0.43 log units) below; measured number inside the range.
By their numbers in this assay, from the lowest: compounds 3 and 1 (each within the scatter of the next); then compounds 2 and 4 (each within the scatter of the next).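

Swapping phenyl for methyl on the aromatic nitrogen gives an 8.1-fold higher number from compound 3 to compound 4 (0.91 log units; beyond the scatter) in this assay, a step beyond the scatter. Going by these compounds alone, this is the first measured sign that the group at this position affects the number, although compound 4 still gives 12 nM without the aromatic ring. The data offer no explanation for the shift.

From the compounds shown here alone, it remains open how a cyclohexyl, a benzyl or a pyridyl group would compare on this nitrogen. An ethyl or a longer chain could also show whether chain size alone tracks the number.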